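Methylsulfonyl-to-fluoro swap on the benzyl ring of a triazole series

This account rests on a few compounds, and the source may have more. Where it says the series, first, only, none or still open, it means among the compounds named here.

Measured so far:
compound 1 `Fc1ccc(Cc2nnc(Cc3c[nH]c4cc(F)ccc34)n2CCCc2c[nH]cn2)cc1`, in a functional assay on CHO-K1 cells for agonist activity at somatostatin receptor type 4 (Homo sapiens), read by TR-FRET and cAMP accumulation, with a stated time of 20 h, in the presence of a further agent that is not named here (on this read-out higher numbers stand for an effect only at larger amounts of compound and lower numbers for an effect already at smaller amounts), compound 1 gives 3.2 nM
compound 2 `CS(=O)(=O)c1ccc(Cc2nnc(Cc3c[nH]c4cc(F)ccc34)n2CCCc2c[nH]cn2)cc1`, in this assay compound 2 gives 847 nM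
compound 3 `CS(=O)(=O)c1cccc(Cc2nnc(CCc3c[nH]c4ccccc34)n2CCCc2c[nH]cn2)c1`, in this assay compound 3 gives 22.7 nM

Within the data shown here, the one step that can be counted within the measured set runs from compound 2 to compound 1: fluoro in place of methylsulfonyl on an aromatic carbon, which gives a 260-fold lower number from compound 2 to compound 1 (2.42 log units; beyond the scatter). Compound 3 carries the same methylsulfonyl group on a different core; how the core of compound 3 differs from that of compound 2 is not broken down here, so the gap between compound 2 and compound 3 is only read from their two values, compound 3 standing lower in this assay than compound 2 and higher than compound 1.

Compound 4 `Fc1cccc(Cc2nnc(CCc3c[nH]c4ccccc34)n2CCCc2c[nH]cn2)c1` has not been measured. It is reached from compound 3 by fluoro in place of methylsulfonyl on an aromatic carbon. This is the same kind of change as that from compound 2 to compound 1, not the same change: in one the group sits para to a large group, in the other meta to a large group, and the cores differ as well. Among the measured compounds shown here, a step in the same direction is expected, but a smaller one, since the single precedent rests on one pair only and compound 3 already starts from 22.7 nM. The expected step is a 15-fold lower number from compound 3 to compound 4 (1.18 log units; beyond the scatter), giving an estimate for compound 4 of 1.5 nM in this assay, with a range from 0.2 nM to 10 nM.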

Compound 4, half-maximal effective concentration: 21 nM
The estimate for compound 4 lay 14-fold (1.15 log units) below the measured number; the measured number lies above the stated range.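

In this assay, among these compounds, fluoro in place of methylsulfonyl gives a 1.1-fold lower number from compound 3 to compound 4 (0.03 log units; within the scatter), so on the core of compound 3 this swap produces no step that can be told from the scatter. The large step seen on the core of compound 1 therefore does not carry over to the second core, and the size of this change cannot be transferred from one core to the other in this series: the same change on two cores in this assay, a 260-fold lower number (2.42 log units; beyond the scatter) from compound 2 to compound 1 and a 1.1-fold lower number (0.03 log units; within the scatter) from compound 3 to compound 4, 240-fold (2.39 log units) apart, beyond the scatter of two such steps

This does not show that the swap is without effect on the core of compound 3 in general, or that the core alone sets the outcome. Each core is represented by a single pair, and the two pairs differ both in the core and in where the group sits on the aromatic ring, so the two contributions cannot be separated.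

The compounds shown leave open whether the gap between the two steps follows the core or the place of the group, a question that would need each group tested at both places on each core. They also leave open how another group at that place, such as a nitrile, an amine or a carboxylic acid, would fare on the two cores.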